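The source may hold more compounds than are shown below. What is called first, only, known or untested is meant among the compounds shown, and "the series" means these compounds.

Compound 1 `CNC(=O)CCSc1ccc2c(/C=C/c3ccccn3)n[nH]c2c1` carries a methyl on the amide-type nitrogen. In an ADME assay on BaF3 cells (Mus musculus) for antiproliferative activity, read by CCK-8 assay, with a stated time of 72 h (on this read-out higher numbers stand for weaker inhibition of growth and lower numbers for stronger inhibition of growth), compound 1 gives > 10000 nM, which is a limit of the assay and not a number. Compound 2 `CN(C)c1cccc(NC(=O)CCSc2ccc3c(/C=C/c4ccccn4)n[nH]c3c2)c1` and compound 3 `Cc1ccc(NC(=O)CCSc2ccc3c(/C=C/c4ccccn4)n[nH]c3c2)cc1` carry aryl groups at the same nitrogen. In this assay compound 2 gives > 10000 nM, again a limit. In this assay compound 3 gives > 10000 nM, also a limit. The steps a step that the two limits leave unreadable from compound 1 to compound 2, a step that the two limits leave unreadable from compound 1 to compound 3 and a step that the two limits leave unreadable from compound 2 to compound 3 cannot be sized because of the limit of > 10000 nM in this assay, at which 3 of the 3 values shown sit. Compound 4 `O=C(CCSc1ccc2c(/C=C/c3ccccn3)n[nH]c2c1)Nc1ccc(F)c(C(F)(F)F)c1` differs from compound 1 by 4-fluoro-3-(trifluoromethyl)phenyl in place of methyl on an amide-type nitrogen. The exchanges from compound 1 to compound 2 and from compound 1 to compound 3 bear on it most nearly, each replacing the methyl by an aryl group on the same nitrogen, yet neither moved the read-out off the limit. No readable step exists, so the expectation for compound 4 rests on the three limits alone. For compound 4 the step that the limit leaves unreadable from compound 1 to compound 4 is expected, with a value most probably sitting again at the limit. Compound 4 is estimated at 15000 nM, with a range from 3000 nM to 60000 nM.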

Compound 4, concentration for 50% growth inhibition: 610 nM
Compound 4: middle estimate off by 25-fold (1.39 log units), on the high side; measured number outside the range, below it.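

In this assay, the substituent on the amide-type nitrogen can move growth inhibition off the limit, as the change to 4-fluoro-3-(trifluoromethyl)phenyl gives an at least 16-fold lower number from compound 1 to compound 4 (1.21 log units; beyond the scatter). An aryl group on this nitrogen is not enough by itself, since the same substituent also gives an at least 16-fold lower number from compound 3 to compound 4 (1.21 log units; beyond the scatter) and an at least 16-fold lower number from compound 2 to compound 4 (1.21 log units; beyond the scatter), so the result depends on which aryl group is present. The earlier steps cannot be read, and each new step has only a minimum size: the limit of > 10000 nM in this assay, at which 3 of the 4 values shown sit.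

The compounds shown do not separate the contribution of the fluoro group from that of the trifluoromethyl group, so a 4-fluorophenyl or a 3-(trifluoromethyl)phenyl on the same nitrogen would be informative. Also open, going by these compounds, is how a pyridyl ring or a carboxylic acid on this aryl group would read out in this assay.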